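This account rests on a few compounds, and the source may have more. Where it says the series, first, only, none or still open, it means among the compounds named here.

Measured so far:
compound 1 `Cn1cc(-c2n[nH]c3ccc(NC4CCNC4)cc23)cn1` — 132000 nM
compound 2 `Nc1ccc2c(-c3cccnc3)n[nH]c2c1` — 28400 nM

In an assay on isolated protein for inhibition of tyrosine-protein kinase receptor UFO (Homo sapiens), with a stated time of 1.5 h (a higher number here means a weaker inhibitor, a lower number a stronger inhibitor), compound 1 gives 132000 nM, the higher of the two numbers seen here. Compound 2 gives 28400 nM in the same run, a lower number that lies beyond the scatter of the two.

Compound 3 `Cn1cc(-c2n[nH]c3ccc(N[C@@H]4CCNC4)cc23)cn1` is the next compound to be measured. Its difference from compound 1 is confined to stereochemistry: the two compounds have the same atoms and bonds; at least one stereo element is drawn with a configuration in one of them and without one in the other: 1 of 1 stereo elements differ; a stereocentre at a saturated ring carbon is drawn without a configuration in compound 1 and R in compound 3. Among the measured compounds shown here, no pair of measured compounds in this set differs in this way, so there is no measured step to lean on. Resolving one drawn configuration out of an undrawn one is expected to change the number little; if activity is concentrated in the drawn form, the number could come out somewhat lower, otherwise it should stay within the scatter. The expected step is a 1.5-fold lower number from compound 1 to compound 3 (0.17 log units; within the scatter). Compound 3 is therefore estimated at 90000 nM, with a range of 30000 nM to 300000 nM.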

Compound 3, half-maximal inhibitory concentration: 37000 nM
Estimate against measurement, compound 3: 2.4-fold (0.39 log units) above, within the range that was stated.
By their numbers in this assay, from the lowest: compounds 2 and 3 (each within the scatter of the next); then compound 1.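

In this assay, among the compounds shown here, the stereocentre at the saturated ring carbon is the first place where a single change can be read, and going from undrawn to R gives a 3.6-fold lower number from compound 1 to compound 3 (0.55 log units; beyond the scatter). The step is beyond the scatter, so the drawn configuration at this carbon counts in this assay, which two compounds differing in several places could not show. The atoms and bonds stay the same, so the step can be traced only to one structural difference: the fact that one of compounds 1 and 3 is drawn with a defined configuration and the other without, at the place where they differ

The compounds shown give no reading of the S configuration at this carbon, so it stays open how the number for that form compares with compound 3 at 37000 nM. Also open, from the compounds shown here alone, is how the number responds if a carboxylic acid or a longer chain takes the place of the saturated ring.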